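Shortening the Chain to the Silyl Ether Oxygen

The source may hold more compounds than are shown below. What is called first, only, known or untested is meant among the compounds shown, and "the series" means these compounds.

Compound 1 `CC(C)(C)[Si](OCCc1ccc(=O)[nH]n1)(c1ccccc1)c1ccccc1` in a functional assay on aorta (Rattus norvegicus); a higher number here means a weaker inhibitor, a lower number a stronger inhibitor: 56200 nM
Compound 2 `Cn1nc(CCO)ccc1=O` in this assay: a limit of the assay, > 100000 nM

Within the data shown here, compound 1 gives the only actual number in the set, and that number already marks it as a weak inhibitor. Compound 2 returns no number at all but a limit, (the limit of > 100000 nM in this assay, at which 1 of the 2 values shown sits). Among the measured compounds shown here, no step between two measured compounds is available, so there is nothing yet to show how any single structural change moves the read-out here.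

For the measured compounds named here, compound 3 `CC(C)(C)[Si](OCc1ccc(=O)[nH]n1)(c1ccccc1)c1ccccc1` is the first such step. Relative to compound 1 it carries a group of 7 heavy atoms (4 carbon, 2 nitrogen, 1 oxygen; one six-membered aromatic ring with 2 hetero atoms) in place of a group of 8 heavy atoms (5 carbon, 2 nitrogen, 1 oxygen; one six-membered aromatic ring with 2 hetero atoms), on a saturated chain carbon bound to an oxygen, so the chain that joins the silyl ether oxygen to the ring is one carbon shorter while every other part is kept. Going by the values given here, with no measured step to lean on, the expectation is a change that stays within the usual scatter, in either direction. For compound 3 the value is estimated at 60000 nM, with a likely range from 15000 nM to 200000 nM. This estimate means a step of a 1.1-fold higher number from compound 1 to compound 3 (0.03 log units; within the scatter), which is expected to be no more than the scatter itself.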

Compound 3, half-maximal inhibitory concentration: 62600 nM
Estimate against measurement, compound 3: 1.0-fold (0.02 log units) below; low and high end bracket the measured number.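

In this assay, replacing the group of 8 heavy atoms with the group of 7 heavy atoms, on a saturated chain carbon bound to an oxygen, gives a 1.1-fold higher number from compound 1 to compound 3 (0.05 log units; within the scatter) and so leaves the read-out unchanged within the scatter. This first measured step shows that, for this pair, one carbon more or less in the chain joining the silyl ether oxygen to the ring does not separate the two compounds, and both remain weak inhibitors. No measurement shown offers a reason for this outcome.

Compound 2 still gives only a limit of the assay, > 100000 nM, and so offers no number to compare. Still open, going by these compounds, is whether a longer chain, or an amine in place of the silyl ether oxygen, would move the read-out beyond the scatter.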